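Isoquinolin-4-yl to quinolin-5-yl: same atoms, joined differently

The source may report more compounds than this note shows. Statements on the series, on what has been measured and on what is new or still open speak of the compounds shown alone.

In a physicochemical assay for solubility, read by HPLC, in phosphate buffer, measured as thermodynamic solubility, with a stated time of 24 h, at pH 7.4 (a higher number here means a more soluble compound, a lower number a less soluble compound), compound 1 `C[C@@H]1CN([C@@H](C)CO)C(=O)c2cccc(NC(=O)NCc3cccc4ccccc34)c2O[C@H]1CN(C)S(=O)(=O)c1ccc2c(c1)OCCO2` gives 100 nM while compound 2 `C[C@@H]1CN([C@@H](C)CO)C(=O)c2cccc(NC(=O)N(C)c3cccc4ccccc34)c2O[C@H]1CN(C)S(=O)(=O)c1ccc2c(c1)OCCO2` gives 11200 nM and compound 3 `C[C@@H]1CN([C@@H](C)CO)C(=O)c2cccc(NC(=O)Nc3cncc4ccccc34)c2O[C@H]1CN(C)S(=O)(=O)c1ccc2c(c1)OCCO2` stands highest of the three at 84900 nM so far. Compound 4 `C[C@@H]1CN([C@@H](C)CO)C(=O)c2cccc(NC(=O)Nc3cccc4ncccc34)c2O[C@H]1CN(C)S(=O)(=O)c1ccc2c(c1)OCCO2` differs from it as follows: quinolin-5-yl in place of isoquinolin-4-yl on an amide-type nitrogen with quinolin-5-yl in place of isoquinolin-4-yl on an amide-type nitrogen. Among the measured compounds shown here, no measured step makes this exact swap. The closest guides are a 7.6-fold higher number from compound 2 to compound 3 (0.88 log units; beyond the scatter) and an 850-fold higher number from compound 1 to compound 3 (2.93 log units; beyond the scatter) but each exchanged groups of different make-up, whereas here the counted atoms stay the same. Only a modest step is therefore expected, and with compound 3 at 84900 nM as the top number the expected direction is downward. The estimated change in this assay is a 2.1-fold lower number from compound 3 to compound 4 (0.33 log units; beyond the scatter) and no larger shift is expected. For compound 4 the expected value is 40000 nM within an estimated range from 10000 nM to 120000 nM for repeat measurements.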

Compound 4, solubility: 139000 nM
The estimate for compound 4 lay 3.5-fold (0.54 log units) below the measured number; the measured number lies above the stated range.
By their numbers in this assay, from the lowest: compound 1; then compound 2; then compounds 3 and 4 (each within the scatter of the next).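

In this assay, placing quinolin-5-yl instead of isoquinolin-4-yl on the amide-type nitrogen gives a 1.6-fold higher number from compound 3 to compound 4 (0.21 log units; within the scatter) and so does not separate the two: here, the same atoms joined differently leave the number within the scatter. Compound 4 keeps a wide gap to the earlier naphthalene compounds, with a 12-fold higher number from compound 2 to compound 4 (1.09 log units; beyond the scatter) and a 1400-fold higher number from compound 1 to compound 4 (3.14 log units; beyond the scatter) both beyond the scatter. No measurement shown here offers an explanation for this result.

The compounds shown leave open how a quinolin-5-yl group carrying an amine or a carboxylic acid would read on this nitrogen.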